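Working notes: 3-fluorobenzyl to 3-aminobenzyl

A few compounds are considered here, and "the series" means these few. Any claim that something is new, unique, unknown or untested is made for them only; others in the source may bear on it.

Measured in a toxicity assay on NIH3T3 cells (Mus musculus) for cytotoxicity, read by resazurin assay; a lower number here means that less compound is needed, a higher number that more compound is needed for the effect:
- compound 1 `COC(=O)c1ccc(NCc2cncn2Cc2ccccc2C)cc1-c1ccccc1`: 10000 nM
- compound 2 `COC(=O)c1ccc(NCc2cncn2Cc2ccccc2Cl)cc1-c1ccccc1`: 10000 nM
- compound 3 `COC(=O)c1ccc(NCc2cncn2Cc2cccc(F)c2)cc1-c1ccccc1`: > 1000 nM

Compound 3 reads > 1000 nM, which is a limit and not a number.

The next structure is compound 4 `COC(=O)c1ccc(NCc2cncn2Cc2cccc(N)c2)cc1-c1ccccc1`. The change is amino in place of fluoro on an aromatic carbon, in words amino in place of fluoro on an aromatic carbon, or 3-fluorobenzyl to 3-aminobenzyl.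

Two measured steps end at the limit: a step that the limit leaves unreadable from compound 1 to compound 3 and a step that the limit leaves unreadable from compound 2 to compound 3. Going by the values given here, the only readable step is no change at the digits printed from compound 1 to compound 2 (within the scatter), a chloro for methyl exchange. Among the compounds with values here, no measured step involves an amino group, so the support is thin.

On that single step, and with compound 2 at 10000 nM, no shift beyond the scatter is expected in this assay, in either direction. The expected step is a step that the limit leaves unreadable from compound 3 to compound 4.

Compound 4 is estimated at 8000 nM, with an expected range of 2500 nM to 20000 nM.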

Compound 4, half-maximal effective concentration: > 10000 nM
Compound 4 ended at the assay's limit; the forecaster's own chance of this, stated with the estimate: 50%; middle value at least 1.2-fold (0.09 log units) away from the limit.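

Compound 4 is the first compound shown with an amino group on this aromatic carbon, and in this assay compound 4 gives > 10000 nM, which is a limit of the assay and not a number: the limit of > 10000 nM in this assay, at which 1 of the 4 values shown sits.

Against the 2-methylbenzyl and 2-chlorobenzyl compounds, the result gives a number no lower from compound 2 to compound 4 (the limit leaves the size open) and a number no lower from compound 1 to compound 4 (the limit leaves the size open). The size of these steps and of the amino for fluoro exchange cannot be read, but an amino group at this place gives no lower number than compound 1 or compound 2.

On these data alone, whether amino and fluoro differ at this place stays open, as neither compound 3 nor compound 4 has a number. As far as these compounds go, what a hydroxy group or an acetamide on this aromatic carbon would give in this assay is also open.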